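The source may hold more compounds than are shown below. What is called first, only, known or untested is meant among the compounds shown, and "the series" means these compounds.

Compound 1 `CC(C)C[C@H](NC1=CC(=O)C=C(C(C)(C)C)C1=O)C(=O)O`: 76500 nM
Compound 2 `C[C@H](NC1=CC(=O)C=C(C(C)(C)C)C1=O)C(=O)O`: 77600 nM
Compound 3 `CSCC[C@H](NC1=CC(=O)C=C(C(C)(C)C)C1=O)C(=O)O`: not yet measured

In a functional assay on K562 cells (Homo sapiens) for cytotoxicity, read by MTT assay, with a stated time of 72 h (a lower number here means a stronger inhibitor, a higher number a weaker inhibitor), compound 2 gives 77600 nM, within the scatter of compound 1. Passing to compound 3 is (methylsulfanyl)methyl in place of hydrogen on a saturated chain carbon, two bonds along the chain from an amine nitrogen and a carbonyl carbon; cut one bond further out, this reads methyl to 2-(methylsulfanyl)ethyl. Among the compounds with values here, the only measured step at this place is a 1.0-fold higher number from compound 1 to compound 2 (0.01 log units; within the scatter), so swapping hydrogen for isopropyl there left the number unmoved. One step is thin evidence, and none involves sulfur. The expected step is a 1.1-fold lower number from compound 2 to compound 3 (0.04 log units; within the scatter), with no shift beyond the scatter anticipated. For compound 3 the estimate is 70000 nM, with an expected range of 38000 nM to 125000 nM.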

Compound 3, half-maximal inhibitory concentration: 88500 nM
Beside the measured number, compound 3's estimate is 1.3-fold (0.10 log units) below it; low and high end bracket the measured number.
By their numbers in this assay, from the lowest: compounds 1, 2 and 3 (each within the scatter of the next).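

In this assay, the sulfur-bearing (methylsulfanyl)methyl now joins isopropyl at this saturated chain carbon without moving the number: the change gives a 1.1-fold higher number from compound 2 to compound 3 (0.06 log units; within the scatter) and, set against isopropyl, a 1.2-fold higher number from compound 1 to compound 3 (0.06 log units; within the scatter). The position has thus tolerated a sulfur-containing chain as well as a branched carbon chain, with all three compounds reading alike. No measurement available here accounts for this flat response. Open, on these data alone, is whether a primary amine, a carboxylic acid or a phenyl ring on this carbon would shift the number beyond the scatter. Also open, as far as these compounds go, is whether any change here matters while the shared core stays the same.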